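This account rests on a few compounds, and the source may have more. Where it says the series, first, only, none or still open, it means among the compounds named here.

In a functional assay on RPMI-8226 cells (Homo sapiens) for antiproliferative activity, read by radiometric assay, with a stated time of 72 h (on this read-out lower numbers stand for stronger inhibition and higher numbers for weaker inhibition), compound 1 (`O=C(CCCCCCC(=O)Nc1cc2ncnc(Nc3ccc(Cl)cc3F)c2s1)NO`) gives 1900 nM and compound 2 (`N#Cc1cccc(Nc2ncnc3cc(NC(=O)CCCCCCC(=O)NO)sc23)c1`) gives 1580 nM on the same read-out, so the two stand level within the usual scatter. Compound 3 (`CCc1ccc(Nc2ncnc3cc(NC(=O)CCCCCCC(=O)NO)sc23)cc1`) keeps the shared core of compound 2 and changes one group (4-ethylphenyl in place of 3-cyanophenyl on a nitrogen on an aromatic ring) with 4-ethylphenyl in place of 3-cyanophenyl on a nitrogen on an aromatic ring. For the measured compounds named here, only one measured step bears on this change. It was made at the same place (a 1.2-fold lower number from compound 1 to compound 2 (0.08 log units; within the scatter)) and it stayed within the scatter. Going by the values given here, a single step is thin evidence, and no compound carrying an ethyl group has been measured yet. No step beyond the scatter is therefore expected in this assay (a 1.0-fold higher number from compound 2 to compound 3 (0.01 log units; within the scatter)) for this swap. Compound 3 is expected to read 1600 nM with an estimated range of 700 nM to 3600 nM in this assay once it is measured.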

Compound 3, half-maximal inhibitory concentration: 2540 nM
Compound 3: middle estimate off by 1.6-fold (0.20 log units), on the low side; the measured number falls inside the stated range.
By their numbers in this assay, from the lowest: compounds 2, 1 and 3 (each within the scatter of the next).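

In this assay swapping 3-cyanophenyl for 4-ethylphenyl on the nitrogen gives a 1.6-fold higher number from compound 2 to compound 3 (0.21 log units; within the scatter) and swapping 4-chloro-2-fluorophenyl for 4-ethylphenyl gives a 1.3-fold higher number from compound 1 to compound 3 (0.13 log units; within the scatter) and both steps stay within the scatter. The three compounds now carry a nitrile, two halogens or an ethyl group on the phenyl ring, and this position has so far shown no step beyond the scatter, even with a group that has no hydrogen-bond acceptor. Nothing available explains the small differences among these three compounds.

On these data alone, all three groups are substituted phenyl rings, so it remains open whether a phenyl ring carrying an amine or a carboxylic acid would move the number beyond the scatter. As far as these compounds go, it is also open whether a longer chain in place of the ethyl group would do so.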